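The source may hold more compounds than are shown below. What is called first, only, known or untested is meant among the compounds shown, and "the series" means these compounds.

Compound 3 `CCc1cc(C(C)=O)c(O)cc1OCCCCCC(C)(C)c1nnn(C)n1` gives 95% in an assay on isolated protein for inhibition of leukotriene B4 receptor 1 (Homo sapiens), tested at 10 uM (a lower number here means less inhibition, a higher number more inhibition at the concentration tested (going by the name of the read-out)), the highest of the three figures in hand. Compound 2 `CCc1cc(C(C)=O)c(O)cc1OCCCC(C)(C)C(=O)O` gives 89% in this assay, which lies within the usual scatter of the figure for compound 3, so the two cannot be ranked against each other. Compound 1 `CCc1cc(C(C)=O)c(O)cc1OCCCCCCC(C)(C)C#N` gives 65% in this assay and stands apart from both: a number 24 percentage points higher from compound 1 to compound 2 (beyond the scatter) and a number 30 percentage points higher from compound 1 to compound 3 (beyond the scatter).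

Compound 4 `CCc1cc(C(C)=O)c(O)cc1OCCCCCC[S+](C)[O-]` differs from compound 3 in one place: a group of 4 heavy atoms (2 carbon, 1 oxygen, 1 sulfur; no ring) in place of a group of 9 heavy atoms (5 carbon, 4 nitrogen; one five-membered aromatic ring with 4 hetero atoms), on a saturated chain carbon, five bonds along the chain from an oxygen on an aromatic ring. Within the data shown here, the step that bears most directly on it is the one from compound 1 to compound 3, in which a nitrile gave way to the tetrazole at the same point of the chain and the figure rose. The step from compound 1 to compound 2 likewise shows a larger group with more acceptors raising the figure. Compound 4 reverses that direction, returning to a small group without a ring and with a single acceptor, closer in size to the nitrile of compound 1.

Compound 4 is therefore expected to show a drop in this assay, estimated as a number 25 percentage points lower from compound 3 to compound 4 (beyond the scatter). Compound 4 is estimated at 70%, with a range from 50% to 88%.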

Compound 4, a percentage reported as inhibition, at one concentration (the size of the read-out at that concentration, not a potency): 92%
Compound 4: the middle estimate sits 22 percentage points below what was measured; measured number above the stated range.
By their numbers in this assay, from the lowest: compound 1; then compounds 2, 4 and 3 (each within the scatter of the next).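

The step of a number 3 percentage points lower from compound 3 to compound 4 (within the scatter) shows that, in this assay, the 1-methyl-1-(2-methyl-2H-tetrazol-5-yl)ethyl group and its ring are not required at this place on the chain: a group of 4 heavy atoms with no ring serves as well there. The step of a number 3 percentage points higher from compound 2 to compound 4 (within the scatter) places compound 4 level with the carboxylic acid of compound 2 too, while a number 27 percentage points higher from compound 1 to compound 4 (beyond the scatter) shows that a small group without a ring does not by itself bring the figure down to that of compound 1, so the size of the group and the presence of a ring do not account for the gap between compound 1 and the other three. No measurement at hand explains why these different groups give matching figures.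

Going by these compounds, with compounds 2, 3 and 4 all read at one concentration and within the scatter of their neighbours, the figures do not separate them, and their potencies remain unknown. On these data alone, it also remains open how an amine or a primary amide would fare at this place, and whether the group of compound 4 would hold its figure on a shorter or a longer chain.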